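This account rests on a few compounds, and the source may have more. Where it says the series, first, only, none or still open, it means among the compounds named here.

Measured so far in an ADME assay (liver) for metabolic stability, with Liver microsome (Homo sapiens) as the target, using microsomes and NADPH, with a stated time of 30 min, tested at 1 uM; on this read-out lower numbers stand for slow clearance and higher numbers for fast clearance:
- Compound 1 `COc1cc(C(O)(C(F)(F)F)C(F)(F)F)cnc1N1CCN(S(=O)(=O)c2ccc(N)nc2)CC1`: < 14 mL.min-1.g-1
- Compound 2 `COCC#Cc1cc(C(O)(C(F)(F)F)C(F)(F)F)cnc1N1CCN(S(=O)(=O)c2ccc(N)nc2)CC1`: 15 mL.min-1.g-1
- Compound 3 `CCn1cc(-c2cc(C(O)(C(F)(F)F)C(F)(F)F)cnc2N2CCN(S(=O)(=O)c3ccc(N)nc3)CC2)cn1`: 20 mL.min-1.g-1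

Compound 1 shows the entry < 14 mL.min-1.g-1, which is a limit of the assay and not a number. For the measured compounds named here, compound 3 stands level with the only other exact number, as a 1.3-fold higher number from compound 2 to compound 3 (0.12 log units; within the scatter) lies within the scatter. Compound 4 `Nc1ccc(S(=O)(=O)N2CCN(c3ncc(C(O)(C(F)(F)F)C(F)(F)F)cc3-c3cccc(F)c3)CC2)cn1` carries 3-fluorophenyl in place of 1-ethyl-1H-pyrazol-4-yl on an aromatic carbon. Earlier swaps at this place give an at least 1.0-fold higher number from compound 1 to compound 2 (0.02 log units; that floor lies within the scatter) and an at least 1.4-fold higher number from compound 1 to compound 3 (0.15 log units; that floor lies within the scatter), both floors within the scatter, so no step beyond the scatter is expected in this assay. The expected change is a 1.1-fold higher number from compound 3 to compound 4 (0.04 log units; within the scatter). Compound 4 is estimated at 22 mL.min-1.g-1, with an expected range from 12 mL.min-1.g-1 to 42 mL.min-1.g-1.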

Compound 4, intrinsic clearance in microsomes: 25 mL.min-1.g-1
Estimate against measurement, compound 4: 1.1-fold (0.06 log units) below, within the range that was stated.
By their numbers in this assay, from the lowest: compounds 2, 3 and 4 (each within the scatter of the next). At a limit, below all of these: compound 1.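

In this assay, 3-fluorophenyl, a ring of carbon only with no hydrogen-bond acceptors, takes the place of the acceptor-bearing 1-ethyl-1H-pyrazol-4-yl and of 3-methoxyprop-1-yn-1-yl with no step beyond the scatter: a 1.3-fold higher number from compound 3 to compound 4 (0.10 log units; within the scatter) and a 1.7-fold higher number from compound 2 to compound 4 (0.22 log units; within the scatter). Compound 1 holds a limit and not a number: the limit of < 14 mL.min-1.g-1 in this assay, at which 1 of the 4 values shown sits. Its step to the fluorophenyl analogue, an at least 1.7-fold higher number from compound 1 to compound 4 (0.25 log units; that floor lies within the scatter), is therefore a floor only. Still open, on these data alone, is whether an amine or a carboxylic acid on this aromatic carbon would give a step beyond the scatter. As far as these compounds go, how far the methoxy group truly lies from the other groups also stays open.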